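This account rests on a few compounds, and the source may have more. Where it says the series, first, only, none or still open, it means among the compounds named here.

Compound 3 `CCC(C)C(=O)N1CCN(c2nc(=O)c3cc(C(F)(F)F)cc([N+](=O)[O-])c3s2)CC1` stands highest in a physicochemical assay for solubility, read by HPLC (a higher number here means a more soluble compound, a lower number a less soluble compound), among the three compounds measured, giving 104 ug/mL. Compound 2 `O=C(c1ccccc1F)N1CCN(c2nc(=O)c3cc(C(F)(F)F)cc([N+](=O)[O-])c3s2)CC1` gives 3.1 ug/mL, and compound 1 `O=C(CC1CCCCC1)N1CCN(c2nc(=O)c3cc(C(F)(F)F)cc([N+](=O)[O-])c3s2)CC1` gives 0.12 ug/mL. Compound 4 `CCCC(=O)N1CCN(c2nc(=O)c3cc(C(F)(F)F)cc([N+](=O)[O-])c3s2)CC1` differs from compound 3 by hydrogen in place of methyl on a saturated chain carbon bound to a carbonyl carbon and a saturated chain carbon. The steps measured so far are of a different kind: the change an 870-fold higher number from compound 1 to compound 3 (2.94 log units; beyond the scatter) and the change a 34-fold higher number from compound 2 to compound 3 (1.53 log units; beyond the scatter) both replaced a ring with the sec-butyl chain, whereas the change to compound 4 only shortens that chain by one carbon. Among the measured compounds shown here, no measured step trims a chain in this way, so the expected step of a 1.4-fold higher number from compound 3 to compound 4 (0.16 log units; within the scatter) is modest, likely within or barely beyond the scatter. For compound 4 the expected value is 150 ug/mL, within a range from 50 ug/mL to 450 ug/mL.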

Compound 4, solubility: 2.46 ug/mL
Estimate against measurement, compound 4: 61-fold (1.79 log units) above; measured number below the stated range.
By their numbers in this assay, from the lowest: compound 1; then compounds 4 and 2 (each within the scatter of the next); then compound 3.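

In this assay, removing the methyl from this saturated chain carbon is enough on its own to give a large step, a 42-fold lower number from compound 3 to compound 4 (1.63 log units; beyond the scatter) in this case, so the number depends on that single methyl and not merely on having a chain instead of a ring. Propyl on the carbonyl carbon cannot be told apart from 2-fluorophenyl, as a 1.3-fold lower number from compound 2 to compound 4 (0.10 log units; within the scatter) shows, while a 21-fold higher number from compound 1 to compound 4 (1.31 log units; beyond the scatter) remains a large step. No measurement on hand accounts for the effect of the methyl. Going by these compounds, whether isopropyl, tert-butyl or a longer branched chain on the carbonyl carbon would give a number near that of compound 3 stays open.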